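The source may hold more compounds than are shown below. What is called first, only, known or untested is meant among the compounds shown, and "the series" means these compounds.

Working notes on the series.

Compound 1 `COc1ccc(Nc2nc(N)c(C(=O)c3ccc(OC)c(OC)c3)s2)cc1` and compound 2 `COc1ccc(Nc2nc(N)c(C(=O)c3cc(OC)c(OC)c(OC)c3)s2)cc1` share one core and differ in a single place, namely (methoxy in place of hydrogen on an aromatic carbon). In a functional assay on L1210 cells (Mus musculus) for antiproliferative activity, read by cell counting, with a stated time of 2 days (a lower number here means a stronger inhibitor, a higher number a weaker inhibitor), compound 1 gives 38 nM. In this assay compound 2 gives 1500 nM. The measured step is a 39-fold higher number from compound 1 to compound 2 (1.60 log units; beyond the scatter).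

Compound 3 `Nc1nc(Nc2ccc(F)cc2)sc1C(=O)c1ccccc1` rests on a different core; the difference between the core of compound 3 and the core of compound 1 is not broken down here. In this assay compound 3 gives > 10000 nM, which is a limit of the assay and not a number (the limit of > 10000 nM in this assay, at which 1 of the 3 values shown sits).

Compound 4 `COc1ccc(C(=O)c2sc(Nc3ccc(F)cc3)nc2N)cc1` has not yet been measured in this assay. It differs from compound 3 by methoxy in place of hydrogen on an aromatic carbon. For the measured compounds named here, this is the same kind of change as the one from compound 1 to compound 2, not the same change: in compound 2 the entering methoxy sits ortho to a methoxy group, meta to a large group and meta to a methoxy group, whereas in compound 4 it sits para to a large group.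

Going by the values given here, only one measured instance of this kind of change exists in the set, and it stands in a different surrounding, while compound 3 supplies only a limit, so the expectation is set wide. The step expected in this assay is an at least 4.0-fold lower number from compound 3 to compound 4 (0.60 log units; beyond the scatter). In this assay compound 4 is estimated at 2500 nM, with a range from 200 nM to 25000 nM.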

Compound 4, half-maximal inhibitory concentration: > 10000 nM
Compound 4 ended at the assay's limit; the forecaster's own chance of this, stated with the estimate: 35%; middle value at least 4.0-fold (0.60 log units) away from the limit.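

Compound 3 and compound 4 both sit at the same limit of this assay, which is a limit and not a number, so no step can be read between them: the limit of > 10000 nM in this assay, at which 2 of the 4 values shown sit.

The compounds shown leave open whether phenyl to 4-methoxyphenyl changes activity at all on the core of compound 3, and how that change would compare with a 39-fold higher number from compound 1 to compound 2 (1.60 log units; beyond the scatter).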